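A few compounds are considered here, and "the series" means these few. Any claim that something is new, unique, unknown or untested is made for them only; others in the source may bear on it.

In a functional assay on K562 cells (Homo sapiens) for cytotoxicity, read by MTT assay (on this read-out lower numbers stand for stronger inhibition and higher numbers for weaker inhibition), compound 1 `COc1ccc(/C=C/C(=O)c2ccc(OC)c3c2OC(C)(C)C=C3)cc1O` gives 630 nM and compound 2 `COc1ccc(/C=C/C(=O)c2ccc(OC)c3c2OC(C)(C)C=C3)cc1OC(=O)C1CC1` gives 410 nM, so compound 2 stands level with compound 1 within the scatter. Compound 3 `COc1ccc(/C=C/C(=O)c2ccc(OC)c3c2OC(C)(C)C=C3)cc1CS(C)(=O)=O` differs from compound 2 as follows: (methylsulfonyl)methyl in place of (cyclopropylcarbonyl)oxy on an aromatic carbon. This places (methylsulfonyl)methyl in place of (cyclopropylcarbonyl)oxy on an aromatic carbon. For the measured compounds named here, the only measured step that bears on this position is a 1.5-fold lower number from compound 1 to compound 2 (0.19 log units; within the scatter). Going by the values given here, no measured compound carries (methylsulfonyl)methyl, so no step beyond the scatter is expected in this assay, and no direction is favoured. The expected step is a 1.3-fold higher number from compound 2 to compound 3 (0.13 log units; within the scatter). For compound 3 the estimated value is 550 nM, with an expected range of 190 nM to 1600 nM.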

Compound 3, half-maximal inhibitory concentration: 9240 nM
Compound 3: the middle estimate sits 17-fold (1.23 log units) below what was measured; the whole stated range lies below it.
By their numbers in this assay, from the lowest: compounds 2 and 1 (each within the scatter of the next); then compound 3.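

In this assay this aromatic carbon proves sensitive to the group it carries, which hydroxy and (cyclopropylcarbonyl)oxy, level within the scatter, could not show. Replacing either group with (methylsulfonyl)methyl costs activity, with a 23-fold higher number from compound 2 to compound 3 (1.35 log units; beyond the scatter) and a 15-fold higher number from compound 1 to compound 3 (1.17 log units; beyond the scatter). Nothing available here explains this loss. As far as these compounds go, whether the step follows the loss of the oxygen on the aromatic carbon or the entry of the sulfonyl remains open. A methyl group or an amine on this carbon would help separate the two.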